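The source may report more compounds than this note shows. Statements on the series, on what has been measured and on what is new or still open speak of the compounds shown alone.

Three compounds that share one core and differ only in how their double bonds are drawn have been measured in a functional assay on DU-145 cells (Homo sapiens) for antiproliferative activity, read by WST assay, with a stated time of 72 h; a higher number here means that more compound is needed for the effect, a lower number that less compound is needed. Compound 1 `CCCCCCCC/C=C\c1c(C)c(/C=C/CCCCCCCC)c2[n+](c1C)CCC2` gives 0.2 uM. Compound 2 `CCCCCCCC/C=C\c1c(C)c(/C=C\CCCCCCCC)c2[n+](c1C)CCC2` gives 1 uM. Compound 3 `CCCCCCCC/C=C/c1c(C)c(/C=C/CCCCCCCC)c2[n+](c1C)CCC2` gives 0.8 uM. Among these three numbers compound 3 stands second highest: there is a 1.3-fold lower number from compound 2 to compound 3 (0.10 log units; within the scatter), and a 4.0-fold higher number from compound 1 to compound 3 (0.60 log units; beyond the scatter). The step of a 5.0-fold higher number from compound 1 to compound 2 (0.70 log units; beyond the scatter) is of similar size to the latter.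

Compound 4 `CCCCCCCC/C=C/c1c(C)cc(C)[n+]2c1CCC2` is the next compound. Compared with compound 3 the change is a hydrogen atom in place of a group of 10 heavy atoms (10 carbon; no ring), on an aromatic carbon. None of the three measured steps bears directly on this change, since each of them, as the fact that compounds 1 and 2 differ only in the configuration as drawn, the fact that compounds 1 and 3 differ only in the configuration as drawn and the fact that compounds 2 and 3 differ only in the configuration as drawn make clear, alters only the drawn geometry of a double bond while both chains stay in place. What those steps do show is that the geometry of a chain alone can move the number beyond the scatter. Taking away one entire chain is expected to raise the number more than that, and a step of a 6.3-fold higher number from compound 3 to compound 4 (0.80 log units; beyond the scatter) is estimated. For compound 4 the expected value is 5 uM, with a range from 1 uM to 25 uM.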

Compound 4, concentration for half-maximal effect: 0.6 uM
Beside the measured number, compound 4's estimate is 8.3-fold (0.92 log units) above it, outside the stated range (below it).
By their numbers in this assay, from the lowest: compound 1; then compounds 4, 3 and 2 (each within the scatter of the next).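

On the aromatic carbon two atoms from the ring nitrogen, a hydrogen atom can take the place of the whole 10-carbon chain without a readable difference in this assay: a 1.3-fold lower number from compound 3 to compound 4 (0.12 log units; within the scatter). Among the compounds shown here, the earlier compounds all carried both chains and varied only in double-bond geometry, so this is the first sign that a single chain on the shared core is enough for a number in this range, at least when the remaining double bond is drawn E, as it is in compound 3 and compound 4. Compound 1 remains apart, with a 3.0-fold higher number from compound 1 to compound 4 (0.48 log units; beyond the scatter), but the double bond of the chain that stays is drawn Z in compound 1 and E in compound 4, so this step carries more than the loss of a chain.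

From the compounds shown here alone, whether a shorter chain such as butyl, a lone methyl group or an amine at this position would behave like the hydrogen atom, and whether a Z-drawn double bond on the remaining chain would change the number without the second chain, remains open. What is known about drawn geometry gives no explanation for why the 10-carbon chain can be replaced by hydrogen here.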